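From 4-Ethoxyphenyl to 3-Carboxy-4-Methoxyphenyl

The source may hold more compounds than are shown below. What is called first, only, known or untested is meant among the compounds shown, and "the series" means these compounds.

In a functional assay on HCT-116 cells (Homo sapiens) for antiproliferative activity, read by MTT assay, with a stated time of 48 h (on this read-out higher numbers stand for weaker inhibition and lower numbers for stronger inhibition), compound 1 `COc1ccc(-c2nc3cnccc3n2-c2cc(OC)c(OC)c(OC)c2)cc1O` gives only a limit, > 20000 nM. Compound 2 `COc1ccc(-c2cc3c(cn2)[nH]c(=O)n3-c2cc(OC)c(OC)c(OC)c2)cc1F` reads 910 nM. Compound 3 `CCOc1ccc(-c2cc3c(cn2)[nH]c(=O)n3-c2cc(OC)c(OC)c(OC)c2)cc1` reads 6660 nM, the higher of the two actual numbers. Compound 4 `COc1ccc(-c2cc3c(cn2)[nH]c(=O)n3-c2cc(OC)c(OC)c(OC)c2)cc1C(=O)O` carries 3-carboxy-4-methoxyphenyl in place of 4-ethoxyphenyl on an aromatic carbon. Among the measured compounds shown here, one measured step bears on this change: a 7.3-fold higher number from compound 2 to compound 3 (0.86 log units; beyond the scatter), on going from 3-fluoro-4-methoxyphenyl to 4-ethoxyphenyl. For the measured compounds named here, compound 4 regains the 4-methoxy part of the group in compound 2, which hints at a lower number, but no measured compound carries a carboxy group. The expected change is small, a 1.1-fold lower number from compound 3 to compound 4 (0.05 log units; within the scatter), and not beyond the scatter. For compound 4 the estimated value in this assay is 6000 nM, with an expected range from 1200 nM to 20000 nM.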

Compound 4, half-maximal inhibitory concentration: 3070 nM
Compound 4: the middle estimate sits 2.0-fold (0.29 log units) above what was measured; the range from low to high includes it.
By their numbers in this assay, from the lowest: compound 2; then compound 4; then compound 3. At a limit, above all of these: compound 1.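

Among the compounds shown here, a carboxy group on this ring reads for the first time here, and swapping in the whole 3-carboxy-4-methoxyphenyl group moves the number in this assay only modestly (a 2.2-fold lower number from compound 3 to compound 4 (0.34 log units; beyond the scatter)). With the 4-methoxy part held fixed, carboxy in place of fluoro gives a modest step the other way (a 3.4-fold higher number from compound 2 to compound 4 (0.53 log units; beyond the scatter)). Nothing shown gives a cause for either step. Going by these compounds, what stays open is how an amine, a methyl ester or a primary amide would read in place of the carboxy group of compound 4.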